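A few compounds are considered here, and "the series" means these few. Any claim that something is new, unique, unknown or untested is made for them only; others in the source may bear on it.

Measured so far:
- compound 1, `CC(/C=C/CC(C)CCCC(C)C)=C\C(=O)OCC(C)C`: 7.69
- compound 2, `CCOC(=O)/C=C(C)/C=C/CC(C)CCCC(C)(C)OC(C)=O`: 5.57

In a physicochemical assay for lipophilicity (a lower number here means a more polar compound, a higher number a more lipophilic compound), compound 1 gives 7.69, the higher of the two numbers; compound 2, in the same this assay, gives 5.57, a gap that lies beyond the scatter. The two differ in several places at once, so nothing about any single change can be read from that pair.

Compound 3, `CC(/C=C/CC(C)CCCC(C)C)=C\C(=O)NC(C)C`, has not yet been measured. It differs from compound 1 in one place: isopropylamino in place of isobutoxy on a carbonyl carbon. Within the data shown here, no measured pair shows this change, so the expectation rests on the structural difference alone. The expected step of a number 1.49 log units lower from compound 1 to compound 3 (beyond the scatter) is downward and larger than the scatter. Compound 3 is therefore expected to come in around 6.2, with a likely range from 5.5 to 6.9.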

Compound 3, partition coefficient: 5.65
Compound 3: middle estimate off by 0.55 log units, on the high side; the measured number falls inside the stated range.
By their numbers in this assay, from the lowest: compounds 2 and 3 (each within the scatter of the next); then compound 1.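

In this assay, among these compounds, putting isopropylamino in place of isobutoxy on a carbonyl carbon gives a number 2.04 log units lower from compound 1 to compound 3 (beyond the scatter) and is the first step here that can be tied to a single place. The number at this position therefore depends strongly on the group attached to the carbonyl carbon, in a change that exchanges an ester-type isobutoxycarbonyl for an isopropylcarbamoyl and brings in 1 hydrogen-bond donor. No measurement offered here explains the size of this step.

The pair changes the linking atom and the carbon chain together, so an isobutylamino or an isopropoxy group on the same carbonyl carbon would be needed to tell those two parts apart. As far as these compounds go, whether the step would recur on the core of compound 2, which carries an ethoxy group at this place, also remains open.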